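The source may hold more compounds than are shown below. What is called first, only, known or untested is meant among the compounds shown, and "the series" means these compounds.

The three measured compounds and their values:
compound 1 `CCOC(=O)c1csc2nc(CN3CCN(C)CC3)c(-c3ccc(OC)cc3)n12` gives 69400 nM;
compound 2 `CCOC(=O)c1csc2nc(CN3CCN(C)CC3)c(-c3ccc(Br)cc3)n12` gives 85000 nM;
compound 3 `COc1ccc(-c2c(CN3CCCCC3)nc3scc(C(=O)O)n23)cc1` gives 73100 nM.

All three were tested in a functional assay on PC-3 cells (Homo sapiens) for antiproliferative activity, read by MTT assay, with a stated time of 72 h; a lower number here means a stronger inhibitor, a higher number a weaker inhibitor. Compound 1 and compound 2 differ in one place only: bromo in place of methoxy on an aromatic carbon. That change produced a 1.2-fold higher number from compound 1 to compound 2 (0.09 log units; within the scatter), so the two compounds cannot be told apart by this measurement. Compound 3 carries a core that differs from the core of compound 1; the difference between the two cores is not broken down here. Its value sits close to those of compound 1 and compound 2, and all three numbers lie within the scatter of one another, so no order among them can be read from the data.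

Compound 4 `O=C(O)c1csc2nc(CN3CCCCC3)c(-c3ccc(Br)cc3)n12` has not yet been measured. It stands to compound 3 as compound 2 stands to compound 1: bromo in place of methoxy on an aromatic carbon. The place of the change reads the same in both pairs, so this is the same change made on a second core; it appears in two pairs among the compounds shown. Going by the values given here, the only guide to what it may do is the measured pair, where a 1.2-fold higher number from compound 1 to compound 2 (0.09 log units; within the scatter) was found, together with compound 3, which gives 73100 nM. On that basis compound 4 is expected to show a 1.2-fold higher number from compound 3 to compound 4 (0.07 log units; within the scatter), a step that would stay within the scatter. The estimate for compound 4 in this assay is 85000 nM, with a likely range from 35000 nM to 200000 nM.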

Compound 4, half-maximal inhibitory concentration: > 100000 nM
Compound 4: only a limit was reported; the forecaster's own chance of this, stated with the estimate: 20%; middle value at least 1.1-fold (0.07 log units) from the limit.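

In this assay compound 4 gives > 100000 nM, and this is a limit of the assay, not a number. Bromo in place of methoxy on the second core therefore yields only a floor for the step, an at least 1.3-fold higher number from compound 3 to compound 4 (0.13 log units; that floor lies within the scatter), so the true size of the step could be small or much larger. This fits the small step seen on the first core but does not show that the change carries over from one core to the other with the same size, nor that its size depends on the core: the same change on two cores in this assay, a 1.2-fold higher number (0.09 log units; within the scatter) from compound 1 to compound 2 and an at least 1.3-fold higher number (0.13 log units; that floor lies within the scatter) from compound 3 to compound 4; the limit leaves it open whether they differ

The compounds shown test only methoxy and bromo at this place on the six-membered aromatic ring, so it remains open whether a different group there, such as fluoro, a nitrile or an amine, would give a value clearly apart from those seen so far. Also open, on these data alone, is how much each part of the difference between the two cores matters, for example whether an amide in place of the carboxylic acid of compound 3 would move the value in a way that can be read.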